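The compounds below may be only part of what the source reports. "The series", "measured", "known", "first", "only" and "open" are said of these compounds alone.

Measured compounds:
- compound 1 `O=C(O)CC1CCN(c2ccc(OCc3ccc(Cl)cc3Cl)cc2)C1`: > 33000 nM
- compound 2 `Cc1ccccc1Cc1ccc(N2CCC[C@@]2(C)CC(=O)O)cc1`: > 33000 nM
- compound 3 `Cc1ccccc1Cc1ccc(N2C[C@@H](C)C[C@H]2CC(=O)O)cc1`: 140 nM

Series notes. The read-out is a functional assay on cells for agonist activity at Free fatty acid receptor 1 (Homo sapiens), read by FLIPR and calcium flux, with a stated time of 100 s; on this read-out higher numbers stand for an effect only at larger amounts of compound and lower numbers for an effect already at smaller amounts. Compound 1 reaches only the limit of the assay, > 33000 nM, and no number. Compound 2 likewise gives only a limit, > 33000 nM. For the measured compounds named here, compound 3 is the single compound of the three with a numerical result, 140 nM in this assay ; the two other results sit at the limit of > 33000 nM in this assay, at which 2 of the 3 values shown sit, so no measured step between two numbers is available, and where compound 3 stands can be said only as: the one compound with a measurable effect.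

The next compound, compound 4 `Cc1ccccc1Cc1ccc(N2C[C@@H](c3ccccc3)C[C@H]2CC(=O)O)cc1`, differs from compound 3 by phenyl in place of methyl on a saturated ring carbon. Going by the values given here, no comparable step has been measured, so the direction is open. The expectation is a step of a 2.1-fold higher number from compound 3 to compound 4 (0.33 log units; beyond the scatter) that may well remain within the usual scatter, with a loss judged somewhat more likely than a gain. Compound 4 is accordingly estimated at 300 nM in this assay , within a range from 60 nM to 2000 nM.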

Compound 4, half-maximal effective concentration: > 17000 nM
Compound 4: only a limit was reported; the forecaster's own chance of this, stated with the estimate: 15%; middle value at least 56-fold (1.75 log units) from the limit.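

Phenyl in place of methyl on this saturated ring carbon, two ring bonds from the ring nitrogen, gives the first readable single change in the series, in this assay: an at least 120-fold higher number from compound 3 to compound 4 (2.08 log units; beyond the scatter). Compound 4 has only a limit and no number, so the size of this step is a bound: the limit of > 17000 nM in this assay, at which 1 of the 4 values shown sits.

The two limits of compound 1 and compound 2 could not show this; the pair compound 3 and compound 4 now shows that a measurable effect at this ring carbon holds with methyl but is lost with phenyl.

The compounds shown leave open whether ethyl or cyclopropyl on this ring carbon would keep the effect, so where between methyl and phenyl it is lost remains unknown. Going by these compounds, what a plain hydrogen in place of methyl would give also stays open.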